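Chalcone-Coumarin Hybrids Against a Leukemia Cell Line

A few compounds are considered here, and "the series" means these few. Any claim that something is new, unique, unknown or untested is made for them only; others in the source may bear on it.

Measured compounds:
- Compound 1, `COC(=O)c1ccc(/C=C/C(=O)c2cc3cc(O)ccc3oc2=O)cc1`: 7100 nM
- Compound 2, `COc1cccc(COc2ccc3cc(C(=O)/C=C/c4ccc(C)cc4)c(=O)oc3c2)c1`: > 50000 nM
- Compound 3, `COC(=O)c1ccc(/C=C/C(=O)c2cc3ccc(O)cc3oc2=O)cc1`: 3700 nM

Three coumarin chalcones were examined in a functional assay on MOLT-4 cells (Homo sapiens) for cytotoxicity, read by MTT assay, with a stated time of 72 h; a higher number here means a weaker inhibitor, a lower number a stronger inhibitor. Compound 1 gives 7100 nM and compound 3 gives 3700 nM in this assay. For compound 2 only a limit is recorded: this assay returns > 50000 nM, which marks the boundary of what the assay reports rather than a measured number, so compound 2 stands at the limit of > 50000 nM in this assay, at which 1 of the 3 values shown sits.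

The next compound, compound 4 `COc1cccc(COc2ccc3cc(C(=O)/C=C/c4cccc(OC)c4OC)c(=O)oc3c2)c1`, follows from compound 2 by a single change: 2,3-dimethoxyphenyl in place of 4-methylphenyl on a double-bonded chain carbon bound to a double-bonded chain carbon. Because compound 2 sits at the limit of > 50000 nM in this assay, at which 1 of the 3 values shown sits, no measured step can be read between compound 2 and compound 4, and the difference cannot be sized from these data. With nothing in the measured compounds pointing toward a gain, compound 4 is expected to stay where compound 2 stands, with the step from compound 2 to compound 4 estimated as a number no higher from compound 2 to compound 4 (the limit leaves the size open). Compound 4 is thus estimated at 50000 nM, within a range from 15000 nM to 100000 nM, and most likely reported again only as a limit.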

Compound 4, half-maximal inhibitory concentration: 22800 nM
For compound 4 the middle estimate is 2.2-fold (0.34 log units) above the measured one; the range from low to high includes it.
By their numbers in this assay, from the lowest: compounds 3 and 1 (each within the scatter of the next); then compound 4. At a limit, above all of these: compound 2.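

In this assay, putting 2,3-dimethoxyphenyl in place of 4-methylphenyl on a double-bonded chain carbon bound to a double-bonded chain carbon gives an at least 2.1-fold lower number from compound 2 to compound 4 (0.34 log units; beyond the scatter). Among these compounds, this is the first single change that can be read, and it shows that the group at this place moves the number, with the rest of compound 2 left as it stands. The value of compound 2 is a limit, so the step has a lower bound but no full size: the limit of > 50000 nM in this assay, at which 1 of the 4 values shown sits.

The compounds shown leave open whether a single methoxy group on this ring would give a similar step, or whether both are needed. They also leave open how an amine or a carboxylic acid at this place would read in this assay.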